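Benzyloxy in Place of Thiophen-3-yl at the Para Position

The source may hold more compounds than are shown below. What is called first, only, known or untested is meant among the compounds shown, and "the series" means these compounds.

Compounds measured:
compound 1 `COc1ccccc1-n1nc(C)c2c1NC(=O)[C@H](C)S[C@@H]2c1ccc(Oc2ccccc2)cc1` — 3300 nM
compound 2 `CCc1ccccc1-n1nc(C)c2c1NC(=O)[C@H](C)S[C@@H]2c1ccc(Oc2ccccc2)cc1` — 1100 nM
compound 3 `Cc1ccccc1-n1nc(C)c2c1NC(=O)[C@H](C)S[C@@H]2c1ccc(-c2ccsc2)cc1` — 1400 nM

Compound 3 holds the second highest of the three numbers in an assay on isolated protein for agonist activity at Bile acid receptor (Homo sapiens), read by AlphaScreen, with a stated time of 30 min; a lower number here means that less compound is needed, a higher number that more compound is needed for the effect. Its value sits close to that of compound 2, within the usual scatter, while compound 1 gives a clearly higher number, beyond the scatter. Compound 4 `Cc1ccccc1-n1nc(C)c2c1NC(=O)[C@H](C)S[C@@H]2c1ccc(OCc2ccccc2)cc1` differs from compound 3 in one place: benzyloxy in place of thiophen-3-yl on an aromatic carbon. Among the compounds with values here, the only measured step, a 3.0-fold lower number from compound 1 to compound 2 (0.48 log units; beyond the scatter), concerns a different position on the core and therefore says nothing direct about this change. Within the data shown here, no measured pair addresses the para substituent. Compound 4 is thus expected to land near compound 3, with a step of a 1.1-fold higher number from compound 3 to compound 4 (0.03 log units; within the scatter) in this assay that may well lie within the scatter. The estimate for compound 4 is 1500 nM, ranging from 600 nM to 4000 nM.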

Compound 4, half-maximal effective concentration: "not active" (no number reported)
For compound 4 the study gives words and no number, so the estimate cannot be set against anything.
By their numbers in this assay, from the lowest: compounds 2 and 3 (each within the scatter of the next); then compound 1.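

Within the data shown here, compound 4 is reported in this assay as "not active", without a number, so no step from compound 3 to compound 4 can be read. Nothing shown offers a reason for this result. The compounds shown leave open how much of the thiophen-3-yl value is lost with benzyloxy.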